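A few compounds are considered here, and "the series" means these few. Any claim that something is new, unique, unknown or untested is made for them only; others in the source may bear on it.

Measured so far:
compound 1 `CNC(=O)CSC(c1ccc(Br)cc1)c1ccc(Br)cc1` — 3010 nM
compound 2 `O=C(CSC(c1ccc(Br)cc1)c1ccc(Br)cc1)NCCCc1ccccc1` — 238 nM

Both compounds share a core and were read in an assay on brain (strain Sprague-Dawley) for displacement of a labelled ligand from sodium-dependent dopamine transporter (Rattus norvegicus), read by scintillation counting, with a stated time of 120 min; on this read-out lower numbers stand for stronger inhibition and higher numbers for weaker inhibition. Compound 1 gives 3010 nM, the highest of the two numbers; its nearest neighbour is compound 2, and the step of a 13-fold lower number from compound 1 to compound 2 (1.10 log units; beyond the scatter) is beyond the scatter, so the amide end of the chain clearly sets the number in this pair.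

Compound 3 `NCCSC(c1ccc(Br)cc1)c1ccc(Br)cc1` is not yet measured. Its change from compound 1 is aminomethyl in place of methylcarbamoyl on a saturated chain carbon bound to a sulfur, so the amide is gone and a primary amine closes the chain. Within the data shown here, no measured step covers this change; the only step known, from compound 1 to compound 2, alters a substituent on the amide nitrogen rather than removing the amide, and shows only that this region can move the number a lot.

Among the measured compounds shown here, with no directly bearing step, the expectation for compound 3 is a modest improvement over compound 1, expected as a 3.3-fold lower number from compound 1 to compound 3 (0.52 log units; beyond the scatter), with wide uncertainty. Compound 3 is therefore estimated at 900 nM, with a range of 150 nM to 5000 nM.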

Compound 3, inhibition constant: 483 nM
Estimate against measurement, compound 3: 1.9-fold (0.27 log units) above; measured number inside the range.
By their numbers in this assay, from the lowest: compound 2; then compound 3; then compound 1.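

In this assay, aminomethyl in place of methylcarbamoyl on a saturated chain carbon bound to a sulfur gives a 6.2-fold lower number from compound 1 to compound 3 (0.79 log units; beyond the scatter), so within this pair a number lower than that of compound 1 does not depend on keeping the amide. The earlier step, a 13-fold lower number from compound 1 to compound 2 (1.10 log units; beyond the scatter), kept the amide and changed only the group on its nitrogen; the new step shows that the methylcarbamoyl group itself can be replaced at this position, with 2 heavy atoms entering where 4 leave and the counts of hydrogen-bond donors and acceptors unchanged. No measurement at hand accounts for the change in the number at this position.

The compounds shown do not tell whether a tertiary amine, a carboxylic acid or a longer chain ending in a primary amine would read differently at the same position. From the compounds shown here alone, it also remains open whether a phenylpropyl group on the nitrogen of the amine would give a step like the one seen on the amide nitrogen.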